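A few compounds are considered here, and "the series" means these few. Any claim that something is new, unique, unknown or untested is made for them only; others in the source may bear on it.

Working notes on the sulfonamide series.

Three compounds share one core and differ only in the aryl group on the sulfonyl sulfur: compound 1 `COc1ccccc1C(=O)NCc1ccc(CNS(=O)(=O)c2cccc3ccccc23)cc1`, compound 2 `COc1ccccc1C(=O)NCc1ccc(CNS(=O)(=O)c2cccc(F)c2)cc1` and compound 3 `COc1ccccc1C(=O)NCc1ccc(CNS(=O)(=O)c2ccccc2C)cc1`. In an assay on MDA-MB-231 cells for displacement of a labelled ligand from C-X-C chemokine receptor type 4 (Homo sapiens), read by fluorescence and microscopy, with stated times of 10 min and 30 min (on this read-out higher numbers stand for an effect only at larger amounts of compound and lower numbers for an effect already at smaller amounts), compound 1 gives only a limit of the assay, > 1000 nM. In this assay compound 2 gives 1000 nM and compound 3 gives 1000 nM. The steps of a number no higher from compound 1 to compound 2 (the limit leaves the size open) and a number no higher from compound 1 to compound 3 (the limit leaves the size open) are open in size because compound 1 sits at the limit of > 1000 nM in this assay, at which 1 of the 3 values shown sits. For the measured compounds named here, the step of no change at the digits printed from compound 2 to compound 3 (within the scatter) lies within the scatter, so compound 2 stands level with compound 3 and at the only numbered readings of the set.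

Compound 4 `Cc1ccccc1C(=O)NCc1ccc(CNS(=O)(=O)c2cccc(F)c2)cc1` differs from compound 2 on the other side of the core: methyl in place of methoxy on an aromatic carbon. Going by the values given here, none of the three measured steps concerns this position; all of them exchange the aryl group on the sulfonyl sulfur, and the one numbered step among them, from compound 2 to compound 3, is flat. There is thus no measured guide to the size of the change toward compound 4, and no direction is indicated. The expected step is no change at the digits printed from compound 2 to compound 4 (within the scatter), a change not beyond the scatter. Compound 4 is therefore estimated at 1000 nM in this assay, with a range from 300 nM to 3000 nM, and a fair chance that only a limit is reported.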

Compound 4, effective concentration (reported as EC, without a stated level of effect): 100 nM
Compound 4: the middle estimate sits 10-fold (1.00 log units) above what was measured, and the stated range ends above it.
By their numbers in this assay, from the lowest: compound 4; then compounds 2 and 3 (each within the scatter of the next).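

In this assay, for the compounds shown here, the exchange of 2-methoxyphenyl for 2-methylphenyl on the carbonyl gives a 10-fold lower number from compound 2 to compound 4 (1.00 log units; beyond the scatter) and is the first numbered step of the set to lie beyond the scatter. Going by these compounds alone, the earlier steps all exchanged the aryl group on the sulfonyl sulfur, and their one numbered step, no change at the digits printed from compound 2 to compound 3 (within the scatter) in the same read-out, gave no sign that the reading could move; this side of the shared core does move it, at least with the 3-fluorophenyl group on the sulfur. Methoxy carries one hydrogen-bond acceptor and methyl none, but nothing to hand ties the step to that count or to any other difference between the two groups.

As far as these compounds go, the exchange is seen here only with 3-fluorophenyl on the sulfur, so whether it holds with the 2-methylphenyl group of compound 3 or the naphthalen-1-yl group of compound 1 stays open. Also open, from the compounds shown here alone, is how other groups at this place would read, such as ethyl, chlorine, an amine or a carboxylic acid.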